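From ethoxy to butoxy: expected cytotoxicity of compound 3

The source may report more compounds than this note shows. Statements on the series, on what has been measured and on what is new or still open speak of the compounds shown alone.

Of the compounds shown here, two have been read so far in an ADME assay on RAW264.7 cells (Mus musculus) for cytotoxicity, read by MTT assay, with a stated time of 24 h, in the absence of a further agent (on this read-out higher numbers stand for weaker inhibition and lower numbers for stronger inhibition), and neither gives a number. Compound 1 (`O=C1OC(Cc2nc(Cc3ccccc3)no2)c2ccccc21`) gives > 40000 nM as a limit of the assay. Compound 2 (`CCOc1ccc(C(O)C2OC(=O)c3c(OC)cc(OC)cc32)cc1`) gives > 40000 nM as a limit of the assay as well. Compound 2 thus sits at the limit of > 40000 nM in this assay, at which 2 of the 2 values shown sit, and no order within the series can be read from it.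

Compound 3 (`CCCCOc1ccc(C(O)C2OC(=O)c3c(OC)cc(OC)cc32)cc1`) differs from compound 2 by ethyl in place of hydrogen on a saturated chain carbon, two bonds along the chain from an oxygen on an aromatic ring with ethyl in place of hydrogen on a saturated chain carbon, two bonds along the chain from an oxygen on an aromatic ring, so that ethoxy becomes butoxy. Among the compounds with values here, no measured pair shows a change of this kind, and the expectation rests on compound 2 alone. No step beyond the scatter is expected in this assay in either direction, and a further limit is the likeliest report. The expected change is a step that the limit leaves unreadable from compound 2 to compound 3 and it stays within the scatter. Compound 3 is estimated at 50000 nM with an expected range of 20000 nM to 120000 nM if a number is reported.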

Compound 3, half-maximal inhibitory concentration: > 40000 nM
Compound 3: a limit, no number; the forecaster's own chance of this, stated with the estimate: 80%; the middle value lies beyond the limit too.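

In this assay compound 3 gives > 40000 nM, which is a limit of the assay and not a number. With a limit on each side, no step can be read between compound 2 and compound 3. The compounds shown leave open whether ethoxy and butoxy differ at all in this assay, and whether any compound in the series gives a number there.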